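This account rests on a few compounds, and the source may have more. Where it says the series, first, only, none or still open, it means among the compounds named here.

Measured so far in an assay for binding affinity to metabotropic glutamate receptor 5 (Rattus norvegicus); a higher number here means a weaker inhibitor, a lower number a stronger inhibitor:
- compound 1 `N#Cc1ccccc1-c1cc(F)cc(-n2nnc(-c3ccccn3)n2)c1`: 4 nM
- compound 2 `Nc1ccccc1-c1cc(F)cc(-n2nnc(-c3ccccn3)n2)c1`: 7 nM
- compound 3 `Cc1cnccc1-c1cc(F)cc(-n2nnc(-c3ccccn3)n2)c1`: 33 nM

Compound 3 gives the highest number of the three in this assay. The step of an 8.3-fold higher number from compound 1 to compound 3 (0.92 log units; beyond the scatter) and the step of a 4.7-fold higher number from compound 2 to compound 3 (0.67 log units; beyond the scatter) both run upward beyond the scatter, while a 1.8-fold higher number from compound 1 to compound 2 (0.24 log units; within the scatter) stays within it.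

Compound 4 `Cc1ccncc1-c1cc(F)cc(-n2nnc(-c3ccccn3)n2)c1` is the next member. It differs from compound 3 by 4-methylpyridin-3-yl in place of 3-methylpyridin-4-yl on an aromatic carbon. Both compounds keep the same atoms and the same shared core; only the way the methyl and the ring nitrogen are joined within the pyridyl group changes.

Among the compounds with values here, none of the measured steps bears directly on this change: each of them swaps a whole aryl group for another, and no pair among compounds 1 to 3 compares two pyridyl isomers. Within the data shown here, the step of an 8.3-fold higher number from compound 1 to compound 3 (0.92 log units; beyond the scatter) and the step of a 4.7-fold higher number from compound 2 to compound 3 (0.67 log units; beyond the scatter) show only that the group at this position matters at a modest scale. Among the measured compounds shown here, with no comparable step available, the expected step of a 1.1-fold lower number from compound 3 to compound 4 (0.04 log units; within the scatter) is none beyond the scatter, with wide uncertainty in either direction. Compound 4 is therefore estimated at 30 nM in this assay, within a range from 8 nM to 120 nM.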

Compound 4, inhibition constant: 2 nM
Compound 4: the middle estimate sits 15-fold (1.18 log units) above what was measured; the whole stated range lies above it.
By their numbers in this assay, from the lowest: compounds 4, 1 and 2 (each within the scatter of the next, the first and the last beyond it); then compound 3.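

Within this assay, rearranging only the methyl and ring nitrogen within the pyridyl group gives a 17-fold lower number from compound 3 to compound 4 (1.22 log units; beyond the scatter) and is a large change, so at this position the arrangement within the group counts, and not only the choice of aryl group. A methylpyridyl group is also compatible with low numbers here: a 3.5-fold lower number from compound 2 to compound 4 (0.54 log units; beyond the scatter) is a step beyond the scatter, whereas a 2.0-fold lower number from compound 1 to compound 4 (0.30 log units; within the scatter) stays within it, leaving 4-methylpyridin-3-yl and 2-cyanophenyl unseparated. No supporting data accompany these values to explain the difference between the two isomers.

Whether the methyl is needed remains open, as unsubstituted pyridin-3-yl does not appear among these compounds. Also open, going by these compounds, is how a methoxy, chloro or ethyl group in its place on the pyridine would compare.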